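This account rests on a few compounds, and the source may have more. Where it says the series, first, only, none or still open, it means among the compounds named here.

Measured so far: compound 2 `CC(C)NS(=O)(=O)c1ccc(S(=O)(=O)N2CCC[C@@H](C(=O)N3CCN(c4nc(C(C)C)no4)CC3)C2)cc1`, 0.489 h; compound 1 `CCN(CC)S(=O)(=O)c1ccc(S(=O)(=O)N2CCC[C@@H](C(=O)NC3COC3)C2)cc1`, 0.452 h.

In an ADME assay on microsomes from liver (Mus musculus) for metabolic stability, read by LC-MS, with a stated time of 60 min, tested at 10 uM (on this read-out higher numbers stand for a longer-lived compound and lower numbers for a shorter-lived compound), compound 2 gives 0.489 h, the top of the two numbers shown, while compound 1 gives 0.452 h; the gap between the two lies within the scatter. Compound 3 `CCC(CC)S(=O)(=O)c1ccc(S(=O)(=O)N2CCC[C@@H](C(=O)N3CCN(c4nc(C(C)C)no4)CC3)C2)cc1` has not yet been measured. It differs from compound 2 by pentan-3-yl in place of isopropylamino on a sulfonyl sulfur. Going by the values given here, no step between measured compounds covers this change, so its size and direction cannot be read from the data; a step of no more than the scatter, in either direction, is expected. The estimate for compound 3 in this assay is 0.45 h, range 0.2 h to 1 h, meaning an expected step of a 1.1-fold lower number from compound 2 to compound 3 (0.04 log units; within the scatter).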

Compound 3, half-life: 0.13 h
Beside the measured number, compound 3's estimate is 3.5-fold (0.54 log units) above it; the measured number lies below the stated range.
By their numbers in this assay, from the lowest: compound 3; then compounds 1 and 2 (each within the scatter of the next).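

Going by these compounds alone, on a sulfonyl sulfur, pentan-3-yl in place of isopropylamino gives a 3.8-fold lower number from compound 2 to compound 3 (0.58 log units; beyond the scatter) in this assay, so a change at this position alone moves the half-life, which the earlier compounds, differing in more than one place, could not show. The change also removes the hydrogen-bond donor of isopropylamino, but this single step cannot separate that loss from the change of chain. No measurement on hand bears on the cause of the step.

Open, as far as these compounds go, is how tert-butylamino or a cyclopentyl group on the same sulfur would read, which would help separate the role of the nitrogen from that of the carbon chain.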